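This account rests on a few compounds, and the source may have more. Where it says the series, first, only, none or still open, it means among the compounds named here.

Measured compounds:
- Compound 1, `COc1ccc(NS(=O)(=O)c2cc(F)c(F)c(F)c2F)cc1`: 370 nM
- Compound 2, `COc1ccc(NS(=O)(=O)c2c(F)c(F)c(F)c(Br)c2F)cc1`: 220 nM
- Compound 3, `COc1ccc(NS(=O)(=O)c2c(F)cc(F)c(F)c2F)cc1`: 5800 nM

These three share one core and differ only in the halogens on the ring that carries the sulfonyl group. In a functional assay on HeLa cells (Homo sapiens) for cytotoxicity (on this read-out higher numbers stand for weaker inhibition of growth and lower numbers for stronger inhibition of growth), compound 3 gives the highest number of the three: compound 1 gives 370 nM and compound 2 gives 220 nM, both far lower than compound 3, so compound 3 is the weakest inhibitor of growth measured here.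

Compound 4, `COc1ccc(NS(=O)(=O)c2ccc(F)c(F)c2F)cc1`, is the next step. It differs from compound 3 in one place: hydrogen in place of fluoro on an aromatic carbon

For the measured compounds named here, only one measured step concerns the removal of a halogen from this ring, and it is a 26-fold higher number from compound 2 to compound 3 (1.42 log units; beyond the scatter). That step took away bromo, not fluoro, so it is a loose guide at best. Compound 1 and compound 3 carry the same number of fluoro groups in different places and still differ widely, which shows that position matters as much as count. Taking away a further fluoro is therefore expected to move the number of compound 4 somewhat higher than compound 3, an estimated 1.6-fold higher number from compound 3 to compound 4 (0.19 log units; within the scatter), with wide uncertainty.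

Compound 4 is expected to give about 9000 nM in this assay, within a range of 2500 nM to 30000 nM.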

Compound 4, concentration for 50% growth inhibition: > 50000 nM
Compound 4 ended at the assay's limit (the forecaster's own chance of this, stated with the estimate: 10%); middle value at least 5.5-fold (0.74 log units) from the limit.
By their numbers in this assay, from the lowest: compounds 2 and 1 (each within the scatter of the next); then compound 3. At a limit, above all of these: compound 4.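

In this assay compound 4 gives > 50000 nM, which is a limit of the assay and not a number: the limit of > 50000 nM in this assay, at which 1 of the 4 values shown sits.

Even so, the earlier compounds had not shown what losing a single fluoro does, and here the fluoro ortho to a large group proves to matter on its own, since replacing it with hydrogen gives an at least 8.6-fold higher number from compound 3 to compound 4 (0.93 log units; beyond the scatter). A different fluoro is lost in an at least 130-fold higher number from compound 1 to compound 4 (2.13 log units; beyond the scatter), so among these compounds the removal of either fluoro leaves a clear rise in the number.

On these data alone, the true number of compound 4 stays unknown, so the size of both steps has only a lower bound. Also open, as far as these compounds go, is whether a chloro group or an amine at this place would keep the number close to that of compound 3.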